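The compounds below may be only part of what the source reports. "The series", "measured", "known", "first", "only" and "open" are said of these compounds alone.

The series rests on compound 2 `CCOc1ccccc1-c1ccc(-c2nc3cnccc3c(NC(C(N)=O)C3CC3)c2C#N)cc1` and its measured neighbour compound 1 `CCOc1ccccc1-c1ccc(-c2nc3cnccc3c(N[C@H](CC)C(N)=O)c2C#N)cc1`. In a physicochemical assay for lipophilicity, read by HPLC, at pH 7.5 (on this read-out higher numbers stand for higher lipophilicity and lower numbers for lower lipophilicity), compound 1 gives 3, and in this assay compound 2 gives 3, so compound 2 stands level with compound 1 at the digits shown. For the measured compounds named here, the one measured step, no change at the digits printed from compound 1 to compound 2 (within the scatter), therefore shows that swapping one group on the nitrogen on the aromatic ring for a somewhat larger one left the read-out where it was.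

Compound 3 `CCOc1ccccc1-c1ccc(-c2nc3cnccc3c(N[C@H](CC(C)C)C(N)=O)c2C#N)cc1` is not yet measured. It differs from compound 2 in one place: a group of 8 heavy atoms (6 carbon, 1 nitrogen, 1 oxygen; no ring) in place of a group of 7 heavy atoms (5 carbon, 1 nitrogen, 1 oxygen; one three-membered non-aromatic ring of carbon only), on a nitrogen on an aromatic ring. Going by the values given here, the only step that bears on this change is the one from compound 1 to compound 2, which was flat, so a step of about the same size is expected here, at most a small rise rather than none. On that basis the step of a number 0.30 log units higher from compound 2 to compound 3 (within the scatter) is expected to stay inside the usual scatter. Compound 3 is thus estimated at 3.3 in this assay, with a likely range from 2.9 to 3.7.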

Compound 3, distribution coefficient: 3.4
Estimate against measurement, compound 3: 0.10 log units below; the range from low to high includes it.
By their numbers in this assay, from the lowest: compounds 1 and 2 (each within the scatter of the next); then compound 3.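

The substituent on the nitrogen on an aromatic ring can move this read-out after all: the flat step from compound 1 to compound 2 had not shown this, whereas replacing the group with one three-membered non-aromatic ring of carbon only by 1-carbamoyl-3-methylbutyl gives a number 0.40 log units higher from compound 2 to compound 3 (beyond the scatter) in this assay. The same group also stands clear of the smaller open-chain group, since isopropyl in place of methyl on a saturated chain carbon, two bonds along the chain from a carbonyl carbon and a nitrogen on an aromatic ring, gives a number 0.40 log units higher from compound 1 to compound 3 (beyond the scatter), which places compound 3 highest of the three in this assay. No measurement shown accounts for either step, so the data give the size of the change but not its origin.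

Going by these compounds, whether the read-out keeps rising with a longer chain, or with a phenyl ring at the end of the chain, remains open. So does the effect of an amine or a carboxylic acid at that chain carbon, and whether the opposite stereocentre in the 1-carbamoyl-3-methylbutyl group would read the same.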